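This account rests on a few compounds, and the source may have more. Where it says the series, first, only, none or still open, it means among the compounds named here.

In a functional assay on ACHN cells (Homo sapiens) for inhibition, read by sulforhodamine B assay, with a stated time of 48 h (a higher number here means a weaker inhibitor of growth, a lower number a stronger inhibitor of growth), compound 1 `COc1cc(-c2nn(-c3cccc(NC(=O)Nc4cc(C(F)(F)F)cc(C(F)(F)F)c4)c3)cc2-c2ccncc2)ccc1Cl` gives 5720 nM. Compound 3 `O=C(Nc1cccc(-n2cc(-c3ccncc3)c(-c3ccc(Cl)c(O)c3)n2)c1)Nc1ccc(Cl)c(Cl)c1` reaches only a limit of this assay, > 32500 nM. Compound 2 `COc1cc(-c2nn(-c3cccc(NC(=O)c4cccc(C(F)(F)F)c4)c3)cc2-c2ccncc2)ccc1Cl` also reaches only a limit in this assay, > 50000 nM. Compound 2 thus stands at the weak end of the three values, with no number of its own, as the limit of > 50000 nM in this assay, at which 1 of the 3 values shown sits, shows. Compound 4 `COc1cc(-c2nn(-c3cccc(NC(=O)Nc4cccc(C(F)(F)F)c4)c3)cc2-c2ccncc2)ccc1Cl` differs from compound 2 in one place: (3-(trifluoromethyl)phenyl)amino in place of 3-(trifluoromethyl)phenyl on a carbonyl carbon. Among the measured compounds shown here, no measured step of this kind is available, but compound 1, built with a urea of the same kind, reaches a number in this assay, 5720 nM, while compound 2 does not, so a step toward a stronger inhibitor of growth is expected, an at least 5.0-fold lower number from compound 2 to compound 4 (0.69 log units; beyond the scatter). Compound 4 is estimated at about 10000 nM, within 3000 nM to 40000 nM.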

Compound 4, concentration for total growth inhibition: 3720 nM
Compound 4: the middle estimate sits 2.7-fold (0.43 log units) above what was measured; low and high end bracket the measured number.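

In this assay, among the compounds shown here, (3-(trifluoromethyl)phenyl)amino in place of 3-(trifluoromethyl)phenyl on a carbonyl carbon gives the first one-place step at this position, an at least 13-fold lower number from compound 2 to compound 4 (1.12 log units; beyond the scatter). The start of that step is a limit, not a number, held by compound 2: the limit of > 50000 nM in this assay, at which 1 of the 4 values shown sits. Hydrogen in place of trifluoromethyl on an aromatic carbon stays within the scatter, a 1.5-fold lower number from compound 1 to compound 4 (0.19 log units; within the scatter).

On these data alone, whether a carbamate oxygen or a methylene in place of the amino nitrogen would give a similar number stays open.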